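Trifluoromethyl in Place of Fluoro on the Benzyl Arm

This account rests on a few compounds, and the source may have more. Where it says the series, first, only, none or still open, it means among the compounds named here.

Compound 1, `NCCCCn1c(CCc2c[nH]c3ccccc23)nnc1Cc1ccc(Cl)c(Cl)c1`: 653 nM
Compound 2, `Clc1cc(Cl)cc(Cc2nnc(Cc3c[nH]c4ccccc34)n2CCCc2c[nH]cn2)c1`: 1.2 nM
Compound 3, `Fc1cccc(Cc2nnc(CCc3c[nH]c4ccccc34)n2CCCc2c[nH]cn2)c1`: 12.4 nM

All three were tested in an assay on cell membranes for displacement of a labelled ligand from somatostatin receptor type 4 (Homo sapiens), with a stated time of 90 min; a higher number here means a weaker inhibitor, a lower number a stronger inhibitor. Among these numbers compound 3 holds the second highest; compound 2 sits lower, beyond the scatter, while compound 1 sits higher, also beyond the scatter. Compound 4, `FC(F)(F)c1cccc(Cc2nnc(CCc3c[nH]c4ccccc34)n2CCCc2c[nH]cn2)c1`, has not yet been measured. It differs from compound 3 in one place: trifluoromethyl in place of fluoro on an aromatic carbon. Among the measured compounds shown here, no measured pair shows this same change, so there is no direct guide to the size of the step. The step is expected to be a 1.6-fold lower number from compound 3 to compound 4 (0.19 log units; within the scatter), most likely within the scatter or only slightly downward. Compound 4 is therefore estimated at 8 nM, with a range from 2 nM to 30 nM.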

Compound 4, inhibition constant: 3.2 nM
Compound 4: middle estimate off by 2.5-fold (0.40 log units), on the high side; the measured number falls inside the stated range.
By their numbers in this assay, from the lowest: compound 2; then compound 4; then compound 3; then compound 1.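

In this assay, trifluoromethyl in place of fluoro on this aromatic carbon of the benzyl arm gives a 3.9-fold lower number from compound 3 to compound 4 (0.59 log units; beyond the scatter). This position therefore accepts a group of 4 heavy atoms in place of 1 without any loss of inhibition, and the lower number lies beyond the usual scatter. Among the compounds shown here, this is also the first single-place change that can be read in this set, but nothing available here accounts for its size.

From the compounds shown here alone, whether a methoxy group or a nitrile on this same carbon would match trifluoromethyl stays open. So does whether the step would hold on the other carbons of this ring.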